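The source may report more compounds than this note shows. Statements on the series, on what has been measured and on what is new or still open speak of the compounds shown alone.

Measured so far in a physicochemical assay for solubility, read by turbidimetry, measured as kinetic solubility, at pH 7.4; on this read-out lower numbers stand for lower solubility and higher numbers for higher solubility:
- compound 1 `COc1ccc(F)cc1N1C(=O)CSC1c1cccc(C(=O)NCCCCn2cccn2)c1`: 50000 nM
- compound 2 `COc1ccc(F)cc1N1C(=O)CSC1c1cccc(C(=O)NCCCCc2ccccc2)c1`: 10000 nM

Compound 1 stands higher of the two, at 50000 nM. Within the data shown here, the only measured step is a 5.0-fold lower number from compound 1 to compound 2 (0.70 log units; beyond the scatter). This modest step lies beyond the usual scatter and comes with phenyl in place of 1H-pyrazol-1-yl on a saturated chain carbon.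

Compound 3 `O=C(NCCCCn1cccn1)c1cccc(C2SCC(=O)N2c2ccccn2)c1` has not yet been measured. It keeps the chain of compound 1 and changes a different part of the molecule: pyridin-2-yl in place of 5-fluoro-2-methoxyphenyl on an amide-type nitrogen in a ring. In words, this is pyridin-2-yl in place of 5-fluoro-2-methoxyphenyl on an amide-type nitrogen in a ring.

Among the measured compounds shown here, no measured step touches this place, so the data show no direction for the change. The step of a 5.0-fold lower number from compound 1 to compound 2 (0.70 log units; beyond the scatter) serves only as a rough guide to how far a single change can move this read-out. On that basis, no step beyond the scatter is expected in this assay, though one of modest size in either direction remains possible. The expected step is a 1.2-fold higher number from compound 1 to compound 3 (0.08 log units; within the scatter). For compound 3 the estimated value is 60000 nM, with an expected range of 20000 nM to 150000 nM.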

Compound 3, solubility: 50000 nM
The estimate for compound 3 lay 1.2-fold (0.08 log units) above the measured number, within the range that was stated.
By their numbers in this assay, from the lowest: compound 2; then compounds 1 and 3 (each within the scatter of the next).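

Among these compounds, this is the first measured change at the amide-type nitrogen in the ring, and it swaps 5-fluoro-2-methoxyphenyl for pyridin-2-yl, a group with fewer heavy atoms and a nitrogen in its aromatic ring. In this assay this swap gives no change at the digits printed from compound 1 to compound 3 (within the scatter), so with the 1H-pyrazol-1-yl chain in place this read-out does not separate the two groups, while the change at the end of the chain gave a 5.0-fold lower number from compound 1 to compound 2 (0.70 log units; beyond the scatter) and is so far the only change shown to move the number beyond the scatter. Nothing available offers an explanation for either result, so the finding stands as an observation about these compounds alone.

On these data alone, it remains open whether pyridin-2-yl would leave the number just as unmoved on a molecule whose chain ends in phenyl, as in compound 2, where the starting value is lower and there may be more room to see a difference. Also open, as far as these compounds go, is how this position would respond to a group of a different kind, such as a piperidine ring or a phenyl ring bearing a carboxylic acid.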